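The source may hold more compounds than are shown below. What is called first, only, known or untested is meant among the compounds shown, and "the series" means these compounds.

Measured so far:
compound 1 `CCCCCCc1nc(C(F)(F)F)ccc1CNC(=O)C(C)c1ccc(NS(C)(=O)=O)c(F)c1` — 1.6 nM
compound 2 `C[C@H](C(=O)NCc1ccc(C(F)(F)F)nc1C1CCC(C)(C)CC1)c1ccc(NS(C)(=O)=O)c(F)c1` — 0.3 nM

In an assay on CHO cells for antagonist activity at transient receptor potential cation channel subfamily V member 1 (Homo sapiens), read by FLIPR and calcium flux (on this read-out lower numbers stand for stronger inhibition and higher numbers for weaker inhibition), compound 1 stands highest of the two numbers; compound 2 gives the lower one, and that gap lies beyond the scatter. Compound 3 `CCC1CC=C(c2nc(C(F)(F)F)ccc2CNC(=O)C(C)c2ccc(NS(C)(=O)=O)c(F)c2)CC1` has not yet been measured. It differs from compound 1 in one place: 4-ethylcyclohex-1-en-1-yl in place of hexyl on an aromatic carbon. Going by the values given here, no measured pair shows this exact change, so the size of the step is open. Still, compound 2, which gives 0.3 nM, hints that a ring in this region can go with a lower number. The expected step of a 2.0-fold lower number from compound 1 to compound 3 (0.30 log units; within the scatter) is therefore a modest move toward a lower number. Compound 3 is expected to give about 0.8 nM, between 0.3 nM and 2.5 nM.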

Compound 3, inhibition constant: 0.1 nM
The estimate for compound 3 lay 8.0-fold (0.90 log units) above the measured number, and the stated range ends above it.
By their numbers in this assay, from the lowest: compound 3; then compound 2; then compound 1.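

In this assay, putting 4-ethylcyclohex-1-en-1-yl in place of hexyl on this aromatic carbon next to the ring nitrogen gives a 16-fold lower number from compound 1 to compound 3 (1.20 log units; beyond the scatter). This position therefore accepts a carbon-only ring with a double bond, and here that ring goes with a much lower number than the open chain. No measurement here says why the number falls.

This single step cannot separate the contributions of the ring, its double bond and its ethyl group. Also open, going by these compounds, is how an amine, such as a piperidine ring, would fare at this position.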